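Urea to amide on the shared core: compound 3

The source may report more compounds than this note shows. Statements on the series, on what has been measured and on what is new or still open speak of the compounds shown alone.

Working notes on the series. Compound 1 `COc1cc(-c2nn(-c3cccc(NC(=O)Nc4ccc(Cl)c(Cl)c4)c3)cc2-c2ccncc2)ccc1Cl` is read in a functional assay on ACHN cells (Homo sapiens) for inhibition, read by sulforhodamine B assay, with a stated time of 48 h (a lower number here means a stronger inhibitor of growth, a higher number a weaker inhibitor of growth), where compound 1 gives 1000 nM. Compound 2 `O=C(Nc1cccc(-n2cc(-c3ccncc3)c(-c3ccc(Cl)c(O)c3)n2)c1)Nc1ccc(Cl)c(Cl)c1` in this assay gives 1040 nM. Among the compounds with values here, the single measured step, a 1.0-fold higher number from compound 1 to compound 2 (0.02 log units; within the scatter), replaces methyl by hydrogen on an oxygen on an aromatic ring and stays within the scatter. Compound 1 holds the lowest of the two numbers, its nearest neighbour being compound 2 at a distance within the scatter, so the two are not separated.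

Compound 3 `COc1cc(-c2nn(-c3cccc(NC(=O)c4ccc(Cl)c(C(F)(F)F)c4)c3)cc2-c2ccncc2)ccc1Cl` differs from compound 1 at the carbonyl carbon: 4-chloro-3-(trifluoromethyl)phenyl in place of (3,4-dichlorophenyl)amino on a carbonyl carbon. Within the data shown here, no measured step touches this part of the structure. Among the measured compounds shown here, the only step available, a 1.0-fold higher number from compound 1 to compound 2 (0.02 log units; within the scatter), concerns an oxygen substituent on another ring and gives no guide to the size or direction of this change. No step beyond the scatter is therefore expected, but the uncertainty is wider than for a change with a precedent in the series. For compound 3 the expected number in this assay is 1200 nM, with a range from 300 nM to 5000 nM. This estimate implies a step of a 1.2-fold higher number from compound 1 to compound 3 (0.08 log units; within the scatter), expected to remain within the scatter.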

Compound 3, concentration for 50% growth inhibition: 2730 nM
The estimate for compound 3 lay 2.3-fold (0.36 log units) below the measured number, and the stated range covers the measured number.
By their numbers in this assay, from the lowest: compounds 1 and 2 (each within the scatter of the next); then compound 3.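

Within the data shown here, at the carbonyl carbon of the shared core, this assay shows a first step beyond the scatter: 4-chloro-3-(trifluoromethyl)phenyl in place of (3,4-dichlorophenyl)amino gives a 2.7-fold higher number from compound 1 to compound 3 (0.44 log units; beyond the scatter), whereas the change on the oxygen, a 1.0-fold higher number from compound 1 to compound 2 (0.02 log units; within the scatter), stays within it. The exchange alters two features at once, since the leaving group carries an amino nitrogen with a hydrogen-bond donor and the entering group has no such donor and also bears trifluoromethyl, so the step cannot be divided between the loss of that nitrogen and the change of ring substituents. No accompanying measurement bears on this step.

The compounds shown leave open how the step divides, which (4-chloro-3-(trifluoromethyl)phenyl)amino or 3,4-dichlorophenyl on the same carbonyl carbon would help to settle, as each changes only one of the two features. They also leave open whether the step holds with hydroxy in place of methoxy on the other ring, and how a carboxylic acid or an amine on the ring attached to the carbonyl would read in this assay.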